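A few compounds are considered here, and "the series" means these few. Any claim that something is new, unique, unknown or untested is made for them only; others in the source may bear on it.

Series so far, measured in a functional assay (aorta) with Oryctolagus cuniculus as the target; on this read-out lower numbers stand for tighter binding and higher numbers for weaker binding:

Compound 1 `CCCCc1nc2cccnc2n1Cc1cc(Cl)c(O)c(Cl)c1`: 63.1 nM
Compound 2 `CCCc1nc2c(C)ccnc2n1Cc1cc(Cl)c(O)c(Cl)c1`: 1.26 nM
Compound 3 `Cc1ccnc2c1nc(C(C)C)n2Cc1ccc(-c2ccccc2C(=O)O)cc1`: 31.6 nM

Compound 3 (31.6 nM) lies within the scatter of compound 1 (63.1 nM). Its number is well above that of compound 2 (1.26 nM), a gap beyond the scatter.

The next compound is compound 4 `C/C=C/c1nc2c(C)ccnc2n1Cc1ccc(-c2ccccc2C(=O)O)cc1`, which has prop-1-en-1-yl in place of isopropyl on an aromatic carbon. The rest of compound 3 is unchanged.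

For the measured compounds named here, no measured pair isolates a change at this place, so the evidence is indirect and mixed. Compound 2 (1.26 nM) carries propyl there and gives the lowest number, which hints at room for a lower value with an unbranched chain. Compound 1 (63.1 nM) carries butyl and goes against that hint. Both also differ from compound 3 in more than this one place, so neither gives a clean comparison.

In this assay a modest move to a lower number is expected, estimated as a 2.6-fold lower number from compound 3 to compound 4 (0.42 log units; beyond the scatter) and only slightly beyond the scatter. The estimate for compound 4 is 12 nM (expected range 3 nM to 45 nM).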

Compound 4, dissociation constant: 5.01 nM
The estimate for compound 4 lay 2.4-fold (0.38 log units) above the measured number; low and high end bracket the measured number.
By their numbers in this assay, from the lowest: compound 2; then compound 4; then compounds 3 and 1 (each within the scatter of the next).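

In this assay, for the compounds shown here, replacing isopropyl with prop-1-en-1-yl gives a 6.3-fold lower number from compound 3 to compound 4 (0.80 log units; beyond the scatter), the first reading at this place that isolates a single change. The place, on an aromatic carbon of a five-membered aromatic ring with 2 nitrogen, between two ring nitrogen atoms, therefore responds to the group it carries, even though both groups have 3 heavy atoms, all carbon, and neither has a ring, hydrogen-bond donors or acceptors, or a net charge. Nothing at hand gives a reason for the size of this step.

Going by these compounds alone, the single pair does not divide the step between the double bond outside aromatic rings and the loss of the branched shape, so that split remains open on the core of compound 3 and compound 4. Also open, on these data alone, is how the number moves with other groups at this place, such as cyclopropyl, or a longer unsaturated chain such as but-1-en-1-yl, and whether the direction of the step would hold for them.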